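The compounds below may be only part of what the source reports. "The series", "measured", "known", "first", "only" and "open" are said of these compounds alone.

In a functional assay on MCF7 cells (Homo sapiens) for antiproliferative activity, read by MTT assay, with a stated time of 72 h (a higher number here means a weaker inhibitor, a lower number a stronger inhibitor), three compounds with a shared core have been tested. Compound 1 `O=C(N/N=C/c1ccc(Cl)c(Cl)c1)Nc1ccc(Oc2ccnc3[nH]ccc23)c(F)c1` gives 998 nM, while compound 2 `O=C(N/N=C/c1cc(Br)c(O)c(Br)c1)Nc1ccc(Oc2ccnc3[nH]ccc23)c(F)c1` is reported as "not active" (no number reported). Compound 3 `O=C(N/N=C/c1cccn1CCCN1CCCCC1)Nc1ccc(Oc2ccnc3[nH]ccc23)c(F)c1` gives 4840 nM, the higher of the two numbers and beyond the scatter from the value of compound 1. Compound 4 `O=C(N/N=C/c1cccn1CCCN1CCCC1)Nc1ccc(Oc2ccnc3[nH]ccc23)c(F)c1` is still unmeasured. It carries pyrrolidin-1-yl in place of piperidin-1-yl on a saturated chain carbon, three bonds along the chain from an aromatic nitrogen. For the measured compounds named here, no measured pair shows the effect of this swap, so compound 3 at 4840 nM is the closest guide, and no change beyond the scatter is expected in this assay. The estimated step runs a 1.1-fold lower number from compound 3 to compound 4 (0.03 log units; within the scatter). Compound 4 is expected near 4500 nM, with an estimated range of 2000 nM to 10000 nM.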

Compound 4, half-maximal inhibitory concentration: 4580 nM
Compound 4: the middle estimate sits 1.0-fold (0.01 log units) below what was measured; the range from low to high includes it.
By their numbers in this assay, from the lowest: compound 1; then compounds 4 and 3 (each within the scatter of the next).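

Putting 3-(pyrrolidin-1-yl)propyl where 3-(piperidin-1-yl)propyl stood gives the first step measured at this position, and in this assay it reads a 1.1-fold lower number from compound 3 to compound 4 (0.02 log units; within the scatter) on the same chain. At the end of this chain, then, this assay does not tell the six-membered ring from the five-membered one. Nothing measured here offers a reason for this result. Still open, going by these compounds, is whether a morpholine ring or a dimethylamino group at the chain end would read the same. A shorter chain, such as 2-(pyrrolidin-1-yl)ethyl, is also untested among the compounds shown.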